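Removing a Propyl Group From a Low-Toxicity Nucleoside

The source may hold more compounds than are shown below. What is called first, only, known or untested is meant among the compounds shown, and "the series" means these compounds.

Compound 2 `CCCc1ccc(CCc2cc3cn([C@H]4C[C@H](O)[C@@H](CO)O4)c(=O)nc3o2)cc1` was tested in an ADME assay on HEL cells (Homo sapiens) for cytotoxicity, with a stated time of 3 days; on this read-out higher numbers stand for lower toxicity in this test and lower numbers for higher toxicity in this test. The reading for compound 2, >= 130000 nM, is a limit of the assay rather than a measured number, as the limit of >= 130000 nM in this assay, at which 1 of the 2 values shown sits, shows. Compound 1 `Cc1ccc(C#Cc2cc3cn([C@H]4C[C@H](O)[C@@H](CO)O4)c(=O)nc3o2)cc1` likewise reached only a limit, >= 510000 nM, as the limit of >= 510000 nM in this assay, at which 1 of the 2 values shown sits, shows. Among the measured compounds shown here, no step between these two compounds can therefore be measured. Compound 3 `O=c1nc2oc(CCc3ccccc3)cc2cn1[C@H]1C[C@H](O)[C@@H](CO)O1` differs from compound 2 by hydrogen in place of propyl on an aromatic carbon. In this assay the step expected from this change is a step that the limit leaves unreadable from compound 2 to compound 3, no larger than the scatter and with no clear direction. Compound 3 is thus estimated at 200000 nM, within a range from 90000 nM to 600000 nM, and most likely again only as a limit.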

Compound 3, minimum cytotoxic concentration: > 560000 nM
Compound 3: only a limit was reported (the forecaster's own chance of this, stated with the estimate: 85%); middle value at least 2.8-fold (0.44 log units) from the limit.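

Among the compounds shown here, compound 1, compound 2 and compound 3 are all reported only as limits, and no step between them can be read. As far as these compounds go, the minimum cytotoxic concentration of each compound, and any effect of swapping propyl for hydrogen, stay open.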